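Replacing a Methoxymethyl Amide with a Methylpiperidinyl Amide

A few compounds are considered here, and "the series" means these few. Any claim that something is new, unique, unknown or untested is made for them only; others in the source may bear on it.

Compound 1, `O=C(Nc1ccccn1)c1cccc(Nc2ncc(F)c(Nc3ccc(F)cc3)n2)c1`: 15300 nM in a functional assay on A549 cells (Homo sapiens) for antiproliferative activity, read by sulforhodamine B assay, with a stated time of 3 days; a higher number here means a weaker inhibitor of growth, a lower number a stronger inhibitor of growth
Compound 2, `CN(C)c1ccc(C(=O)Nc2cccc(Nc3ncc(F)c(Nc4ccc(F)cc4)n3)c2)cc1`: > 10000 nM in this assay (a limit)
Compound 3, `COCC(=O)Nc1cccc(Nc2ncc(F)c(Nc3ccc(F)cc3)n2)c1`: 2050 nM in this assay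

Compound 3 has the lowest of the two numbers shown; compound 1 lies nearest, with a 7.5-fold lower number from compound 1 to compound 3 (0.87 log units; beyond the scatter). Compound 2 reaches only the limit (the limit of > 10000 nM in this assay, at which 1 of the 3 values shown sits). Compound 4, `CN1CCC(C(=O)Nc2cccc(Nc3ncc(F)c(Nc4ccc(F)cc4)n3)c2)CC1`, differs from compound 3 by 1-methylpiperidin-4-yl in place of methoxymethyl on a carbonyl carbon. The step that bears on this change is the one at the same carbonyl carbon, an at least 4.8-fold lower number from compound 2 to compound 3 (0.68 log units; beyond the scatter), where a larger ring substituent carried the higher number. A six-membered ring now enters again, so compound 4 is expected to show a higher number than compound 3, roughly a 2.2-fold higher number from compound 3 to compound 4 (0.34 log units; beyond the scatter). For compound 4 the estimate in this assay is 4500 nM, between 1500 nM and 14000 nM.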

Compound 4, concentration for 50% growth inhibition: 1330 nM
Estimate against measurement, compound 4: 3.4-fold (0.53 log units) above, outside the stated range (below it).
By their numbers in this assay, from the lowest: compounds 4 and 3 (each within the scatter of the next); then compound 1.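

In this assay, a non-aromatic six-membered ring on this carbonyl carbon stays level with the open methoxymethyl chain, with a 1.5-fold lower number from compound 3 to compound 4 (0.19 log units; within the scatter). The same ring stands clear of 4-(dimethylamino)phenyl on that carbon, with an at least 7.5-fold lower number from compound 2 to compound 4 (0.87 log units; beyond the scatter), and the whole ((1-methylpiperidin-4-yl)carbonyl)amino group stands clear of (pyridin-2-yl)carbamoyl, with a 12-fold lower number from compound 1 to compound 4 (1.06 log units; beyond the scatter). The value of compound 2 is a limit: the limit of > 10000 nM in this assay, at which 1 of the 4 values shown sits.

The compounds shown leave open whether the ring nitrogen of 1-methylpiperidin-4-yl counts here, which a cyclohexyl group would test. They also leave open whether an open-chain amine such as dimethylaminomethyl would read alike on this carbonyl carbon.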